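Chloro on the fused core: compound 2 to compound 3

The source may report more compounds than this note shows. Statements on the series, on what has been measured and on what is new or still open speak of the compounds shown alone.

In an ADME assay on HEK-293T cells (Homo sapiens) for cytotoxicity, read by MTT assay, with a stated time of 72 h (on this read-out lower numbers stand for stronger inhibition and higher numbers for weaker inhibition), compound 1 `O=C(Nc1nc2ccc(Cl)cc2s1)c1cn(-c2ccccc2)nc1-c1ccc(Cl)cc1` gives 15700 nM. Compound 2 `COc1ccc(-c2nn(-c3ccccc3)cc2C(=O)Nc2nc3ccccc3s2)cc1` gives 18900 nM in this assay, and the two numbers lie within the scatter of each other, so on the numbers shown compound 2 stands level with compound 1. Compound 3 `COc1ccc(-c2nn(-c3ccccc3)cc2C(=O)Nc2nc3ccc(Cl)cc3s2)cc1` differs from compound 2 by chloro in place of hydrogen on an aromatic carbon, a chloro in place of hydrogen on an aromatic carbon. For the measured compounds named here, no step between two measured compounds isolates this change: compound 1 carries the same chloro, but it also differs from compound 2 at the other aryl group, so the pair of compound 1 and compound 2 shows only two values within the scatter and nothing about the chloro alone. In this assay the step from compound 2 to compound 3 is expected to be a 1.1-fold lower number from compound 2 to compound 3 (0.05 log units; within the scatter), none beyond the scatter. Compound 3 is estimated at 17000 nM, with a range from 8000 nM to 36000 nM.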

Compound 3, half-maximal inhibitory concentration: 12600 nM
Estimate against measurement, compound 3: 1.3-fold (0.13 log units) above, and the stated range covers the measured number.
By their numbers in this assay, from the lowest: compounds 3, 1 and 2 (each within the scatter of the next).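

In this assay the chloro in place of hydrogen on an aromatic carbon now stands alone, as 1,3-benzothiazol-2-yl becomes 6-chloro-1,3-benzothiazol-2-yl, and the result is a 1.5-fold lower number from compound 2 to compound 3 (0.18 log units; within the scatter), so this change at this position gives no step beyond the scatter. With that chloro held constant, the other aryl group can also be read alone: methoxy in place of chloro on an aromatic carbon gives a 1.2-fold lower number from compound 1 to compound 3 (0.10 log units; within the scatter), which likewise stays within the scatter. Nothing available bears on what lies behind these numbers.

Both places have so far been probed only with these small changes. Going by these compounds, whether an amine or a carboxylic acid in place of this chloro, or a longer chain in place of the methoxy, would give a step beyond the scatter remains open.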